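The source may report more compounds than this note shows. Statements on the series, on what has been measured and on what is new or still open speak of the compounds shown alone.

The compounds share one core; compound 1 `CSC1(C)C(=O)N(c2ccccc2)c2ncccc21`, compound 2 `CC1(C)C(=O)N(Cc2ccccc2)c2ncccc21` and compound 3 `CC1(C)C(=O)N(Cc2ccc(Cl)cc2)c2ncccc21` have all been tested in a functional assay on the whole organism (Pleural cavity) for inhibition, with Rattus norvegicus as the target, at a dose of 25 mg/kg; a higher number here means more inhibition at the dose given (going by the name of the read-out), a lower number less inhibition. In this assay compound 1 gives 53%, compound 2 gives 12% and compound 3 gives 0%. Going by the values given here, on these numbers compound 2 stands second of the three: compound 3 lies below it, while compound 1 lies far above it, though compound 1 differs from compound 2 in two places, so no single step links them. Among the compounds with values here, the only single-place step among the measured compounds is the change of a number 12 percentage points lower from compound 2 to compound 3 (beyond the scatter), a modest drop for adding chloro.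

Compound 4 `CN1C(=O)C(C)(C)c2cccnc21` is not yet measured. It differs from compound 2 by hydrogen in place of phenyl on a saturated chain carbon bound to an amide-type nitrogen in a ring. Within the data shown here, no measured step removes a phenyl in this way, so the bearing of the one known step is indirect at best, and a step of no clear direction beyond the scatter is expected. The estimate for compound 4 in this assay is therefore 12%, within 0% to 35%, an expected change of no change at the digits printed from compound 2 to compound 4 (within the scatter).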

Compound 4, a percentage reported as inhibition, in the whole organism at one dose (the size of the read-out at that dose, not a potency): 53%
The estimate for compound 4 lay 41 percentage points below the measured number, and the stated range ends below it.
By their numbers in this assay, from the lowest: compound 3; then compound 2; then compounds 1 and 4 (each within the scatter of the next).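

Removing the phenyl on a saturated chain carbon bound to an amide-type nitrogen in a ring gives a number 41 percentage points higher from compound 2 to compound 4 (beyond the scatter) in this assay, so the phenyl is not required for inhibition at this dose, and this position strongly affects the read-out. The earlier step, a number 12 percentage points lower from compound 2 to compound 3 (beyond the scatter), only showed the effect of adding chloro to that phenyl, whereas this step shows the effect of removing the whole ring. Among these three compounds, adding to the phenyl lowers the number and removing it raises the number, but no measurement shown explains either change.

As far as these compounds go, it remains open how an ethyl group, a longer chain or a chain ending in an amine would behave in place of the phenyl. A single dose also leaves open how the compounds would compare at other doses.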